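Bromo for methoxy on the core of compound 1

A few compounds are considered here, and "the series" means these few. Any claim that something is new, unique, unknown or untested is made for them only; others in the source may bear on it.

compound 1, `COc1ccc2[nH]c(=O)c(CN(Cc3ccc(N(C)C)cc3)Cc3ccc(C(C)(C)C)cc3)cc2c1`: 8500 nM
compound 2, `COc1ccc2[nH]c(=O)c(CN(Cc3ccc(C(C)(C)C)cc3)C(C)c3ccc(OC)c(Cl)c3)cc2c1`: > 10000 nM

In a toxicity assay on MDCK cells (Canis lupus familiaris) for cytotoxicity, read by crystal violet staining, with a stated time of 48 h (a higher number here means that more compound is tolerated, a lower number that less compound is tolerated), compound 1 gives 8500 nM. Among the two values shown, compound 1 is the only one that is a number. Compound 2 reaches only a limit of this assay, > 10000 nM, and not a number. For the measured compounds named here, the single measured step, an at least 1.1-fold higher number from compound 1 to compound 2 (0.07 log units; that floor lies within the scatter), is therefore bounded by the limit of > 10000 nM in this assay, at which 1 of the 2 values shown sits, and cannot be read as a change beyond the scatter.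

Compound 3, `CN(C)c1ccc(CN(Cc2ccc(C(C)(C)C)cc2)Cc2cc3cc(Br)ccc3[nH]c2=O)cc1`, differs from compound 1 by bromo in place of methoxy on an aromatic carbon. Going by the values given here, the measured step from compound 1 to compound 2 changes a group on the amine nitrogen, not the fused ring, so it does not bear on this change, and no other step is available. With nothing in the shown data pointing either way, the change from compound 1 to compound 3 is expected to give no step beyond the scatter in this assay, that is a 1.1-fold lower number from compound 1 to compound 3 (0.03 log units; within the scatter). For compound 3 the estimate in this assay is 8000 nM, within a range from 3000 nM to 20000 nM.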

Compound 3, half-maximal cytotoxic concentration: > 10000 nM
Compound 3: no number, only a limit; the forecaster's own chance of this, stated with the estimate: 35%; middle value at least 1.2-fold (0.09 log units) from the limit.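

Bromo in place of methoxy on the aromatic carbon of the shared core gives an at least 1.1-fold higher number from compound 1 to compound 3 (0.07 log units; that floor lies within the scatter), and this is the first reading at this position, since the step to compound 2 changed a group on the amine nitrogen. In this assay compound 3 reaches only a limit, > 10000 nM, and not a number. The result shows that exchanging methoxy for bromo at this carbon does not bring a step to a lower number, but its size remains open, and the floor of the step lies within the scatter: the limit of > 10000 nM in this assay, at which 2 of the 3 values shown sit.

The compounds shown leave open how far compound 3 actually lies from compound 1, and whether the same exchange would read the same way with the 1-(3-chloro-4-methoxyphenyl)ethyl group of compound 2 on the amine nitrogen. They also leave open what a chloro group, a hydroxyl group, an amine or a carboxylic acid at this aromatic carbon would give, as only methoxy and bromo stand there among the three compounds.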